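Z to E at the double bond of compound 2

This account rests on a few compounds, and the source may have more. Where it says the series, first, only, none or still open, it means among the compounds named here.

Measured so far:
compound 1, `COC(=O)/C=C\NC(=O)[C@H](O)C(C)(C)CO`, in an ADME assay on HEK293 cells (Homo sapiens) for inhibition, read by CellTiter-Glo, with a stated time of 96 h, tested at 100 uM (a lower number here means less inhibition, a higher number more inhibition at the concentration tested (going by the name of the read-out)), compound 1 gave "not determined" (no result reported), so no number was reported;
compound 2, `CC(C)(CO)[C@@H](O)C(=O)N/C=C\C(=O)OCc1ccccc1`, for which compound 2 gave 7%;
compound 3, `CCOC(=O)/C=C\NC(=O)[C@H](O)C(C)(C)CO`, for which compound 3 gave -6%.

Compound 2 stands highest of the two numbers available; the nearest is compound 3, and the step of a number 13 percentage points lower from compound 2 to compound 3 (beyond the scatter) lies beyond the scatter though it is modest. Among the measured compounds shown here, that step, methyl in place of phenyl on a saturated chain carbon bound to an oxygen next to a carbonyl group, is the only measured step in this set.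

The unmeasured compound 4, `CC(C)(CO)[C@@H](O)C(=O)N/C=C/C(=O)OCc1ccccc1`, differs from compound 2 as follows: the two compounds have the same atoms and bonds and differ only in configuration as drawn: 1 of 2 stereo elements differ; a double bond is drawn Z in compound 2 and E in compound 4. For the measured compounds named here, no measured pair in the set differs by the geometry of a double bond, so the single measured step does not bear on this change, and there is nothing in the data to suggest a move beyond the scatter in this assay in either direction. Compound 4 is therefore expected to sit near compound 2, with an estimated step of a number 2 percentage points lower from compound 2 to compound 4 (within the scatter). The estimate for compound 4 is 5%, with a range from -12% to 22%.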

Compound 4, a percentage reported as inhibition, at one concentration (the size of the read-out at that concentration, not a potency): 5%
Beside the measured number, compound 4's estimate shows no gap at the digits printed; the range from low to high includes it.
By their numbers in this assay, from the lowest: compound 3; then compounds 4 and 2 (each within the scatter of the next).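

Among the compounds shown here, until this result, the only measured step in the set had put methyl in place of phenyl, and the geometry of the double bond had not been examined on its own in this assay. Turning that double bond from Z to E gives a number 2 percentage points lower from compound 2 to compound 4 (within the scatter), so here the change of geometry stays within the usual scatter, whereas the earlier change gave a number 13 percentage points lower from compound 2 to compound 3 (beyond the scatter). The comparison isolates this one feature, with nothing else in the two structures altered: the fact that compounds 2 and 4 differ only in the configuration as drawn

The compounds shown leave open whether the two geometries would also read alike with methyl in place of phenyl, as that change is known here only with the Z double bond. They also leave open how this assay would respond to a carboxylic acid in place of the ester, or to a longer chain on the ester oxygen, as every compound shown with a number keeps the ester.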